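Compound 3 to compound 4: 4-chlorophenyl on the amide-type nitrogen

The source may hold more compounds than are shown below. What is called first, only, known or untested is meant among the compounds shown, and "the series" means these compounds.

Compound 3 (`O=C1COc2ccc(-c3cnc4ccccc4c3)cc2N1`) gives > 40000 nM in a functional assay on HeLa cells (Homo sapiens) for antiproliferative activity, read by MTT assay, with a stated time of 72 h (a lower number here means a stronger inhibitor, a higher number a weaker inhibitor), and this is a limit, not a number. Compound 2 (`Cc1ccc(N2C(=O)COc3ccc(-c4cnc5ccccc5c4)cc32)cc1`) gives > 40000 nM, also a limit. Only compound 1 (`O=C1COc2ccc(-c3cnc4ccccc4c3)cc2N1C1CCCCC1`), with cyclohexyl on the amide-type nitrogen in a ring, gives a number, 19700 nM.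

Compound 4 (`O=C1COc2ccc(-c3cnc4ccccc4c3)cc2N1c1ccc(Cl)cc1`) has 4-chlorophenyl in place of hydrogen on that nitrogen: 4-chlorophenyl in place of hydrogen on an amide-type nitrogen in a ring.

Among the compounds with values here, three measured steps bear on this change. Hydrogen in place of cyclohexyl gives an at least 2.0-fold higher number from compound 1 to compound 3 (0.30 log units; that floor lies within the scatter). 4-Methylphenyl in place of cyclohexyl gives an at least 2.0-fold higher number from compound 1 to compound 2 (0.30 log units; that floor lies within the scatter). Going by these compounds, the closest comparison, exchanging hydrogen and 4-methylphenyl, gives a step that the two limits leave unreadable from compound 2 to compound 3, so its size is unknown.

The nearest neighbour of compound 4 is compound 2, which stays at its limit of > 40000 nM, so no step beyond the scatter is expected in this assay, and another limit is the likeliest result. The expected change is a number no higher from compound 3 to compound 4 (the limit leaves the size open). Compound 4 is estimated at 40000 nM, with an expected range of 15000 nM to 80000 nM.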

Compound 4, half-maximal inhibitory concentration: > 40000 nM
Compound 4: no number, only a limit; the forecaster's own chance of this, stated with the estimate: 70%; the middle value lies on the limit itself.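

Chloro in place of methyl on the aromatic carbon leaves the series without a number: in this assay, a second substituted phenyl on the amide-type nitrogen in a ring also ends at a limit, and the set now rests largely on that one value: the limit of > 40000 nM in this assay, at which 3 of the 4 values shown sit. The steps from compound 3 and from compound 2 to compound 4 cannot be read, since both ends of each are limits. Against the cyclohexyl group, the change gives an at least 2.0-fold higher number from compound 1 to compound 4 (0.30 log units; that floor lies within the scatter), so compound 1 is the only compound with a number, but it is not shown to stand apart beyond the scatter.

Going by these compounds, whether a straight alkyl chain such as n-butyl, or a chain ending in an amine, on this nitrogen would give a number stays open. Any real difference among compound 2, compound 3 and compound 4 also stays open.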